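The compounds below may be only part of what the source reports. "The series", "measured", "known", "first", "only" and "open" are said of these compounds alone.

Working notes on the series. Going by the values given here, in a functional assay on A549 cells (Homo sapiens) for cytotoxicity, read by WST assay, with a stated time of 24 h (a lower number here means a stronger inhibitor, a higher number a weaker inhibitor), compound 1 `COc1ccc2c(/C=C(\C#N)C(=O)c3c[nH]c4cc(OC)ccc34)c[nH]c2c1` gives 1900 nM, the lower of the two numbers so far, and compound 2 `COc1ccc2c(/C=C(\C#N)C(=O)c3c[nH]c4ccccc34)c[nH]c2c1` gives 9600 nM. The next step leads to the unmeasured compound 3 `COc1ccc2c(C(=O)/C(C#N)=C/c3c[nH]c4cc(F)ccc34)c[nH]c2c1`, with fluoro in place of methoxy on an aromatic carbon. Among the compounds with values here, only one measured step bears on this change, hydrogen in place of methoxy, a 5.1-fold higher number from compound 1 to compound 2 (0.70 log units; beyond the scatter), which is modest and beyond the scatter. Within the data shown here, that step concerns the other methoxy group of compound 1, and no fluoro compound has been measured, so it is a guide by analogy only. A somewhat smaller step towards a higher number is therefore expected in this assay, although no change beyond the scatter remains possible. The expected step is a 2.4-fold higher number from compound 1 to compound 3 (0.37 log units; beyond the scatter). For compound 3 the estimated value is 4500 nM, with an estimated range of 1500 nM to 14000 nM.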

Compound 3, half-maximal inhibitory concentration: 2400 nM
Estimate against measurement, compound 3: 1.9-fold (0.27 log units) above, and the stated range covers the measured number.
By their numbers in this assay, from the lowest: compounds 1 and 3 (each within the scatter of the next); then compound 2.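

In this assay, fluoro in place of methoxy at this position gives a 1.3-fold higher number from compound 1 to compound 3 (0.10 log units; within the scatter), so in this pair the methoxy can be exchanged for fluoro without a change beyond the scatter. The earlier step, a 5.1-fold higher number from compound 1 to compound 2 (0.70 log units; beyond the scatter), concerned the other methoxy group and lay beyond the scatter, so its result does not carry over to this position. No available evidence accounts for this result.

The compounds shown leave open how hydrogen, chloro, an amine or a longer alkoxy chain such as ethoxy would behave at this position. They also leave open whether fluoro in place of the other methoxy group would give a number closer to that of compound 1 than hydrogen does there.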